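This account rests on a few compounds, and the source may have more. Where it says the series, first, only, none or still open, it means among the compounds named here.

Working notes on the series in an ADME assay on HaCaT cells (Homo sapiens) for cytotoxicity, read by MTT assay, with a stated time of 48 h; a lower number here means a stronger inhibitor, a higher number a weaker inhibitor. Of the compounds shown here, two have been read so far: compound 1 `Cc1ccc2[nH]c(-c3cn(-c4ccccc4)nc3-c3ccccc3)nc2c1` and compound 2 `Clc1ccc(-c2nn(-c3ccccc3)cc2-c2nc3cc(Cl)ccc3[nH]2)cc1`. Compound 1 gives > 50000 nM, which is a limit and not a number. Compound 2 gives > 50000 nM, which is again a limit and not a number. Among the measured compounds shown here, the position so far is the limit of > 50000 nM in this assay, at which 2 of the 2 values shown sit, so compound 2 stands at the limit, and the series has no measured step to draw on.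

The next compound is compound 3 `Cc1ccc2[nH]c(-c3cn(-c4ccccc4)nc3-c3ccc(Cl)cc3)nc2c1`. It departs from compound 2 by methyl in place of chloro on an aromatic carbon, counted as methyl in place of chloro on an aromatic carbon. In this assay, no shift beyond the usual scatter is expected for this change, and compound 3 is expected to remain at the limit. That expectation rests on compound 2, whose > 50000 nM is a limit. It draws further support from compound 1, whose > 50000 nM is also a limit. The expected change is a step that the limit leaves unreadable from compound 2 to compound 3. For compound 3 the estimate is 60000 nM, with an expected range of 30000 nM to 120000 nM.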

Compound 3, half-maximal inhibitory concentration: > 50000 nM
Compound 3: only a limit was reported; the forecaster's own chance of this, stated with the estimate: 85%; the middle value does not contradict the limit.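

In this assay, among the compounds shown here, compound 3 gives > 50000 nM, which is a limit and not a number, so no step to compound 3 can be read from compound 1 or compound 2. The compounds shown leave open how far chloro or methyl on the shared core shifts the value in this assay, and whether any member of the series gives a number there: the limit of > 50000 nM in this assay, at which 3 of the 3 values shown sit.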